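3,5-Dihydroxyphenyl replaces 2,3,6-trifluorophenyl on the shared core

This account rests on a few compounds, and the source may have more. Where it says the series, first, only, none or still open, it means among the compounds named here.

Of the compounds shown here, three sharing one core have been tested in a functional assay on K562 cells (Homo sapiens) for antiproliferative activity, with a stated time of 72 h; a lower number here means a stronger inhibitor, a higher number a weaker inhibitor. Compound 1 `COc1ccccc1CNc1ncnc2c1ncn2[C@@H]1O[C@H](CO)[C@@H](O)[C@H]1O` gives 89000 nM. Compound 2 `OC[C@H]1O[C@@H](n2cnc3c(NCc4ccc(F)c(F)c4F)ncnc32)[C@H](O)[C@@H]1O` is reported only as a limit, > 166000 nM. Compound 3 `OC[C@H]1O[C@@H](n2cnc3c(NCc4c(F)ccc(F)c4F)ncnc32)[C@H](O)[C@@H]1O` is likewise reported only as a limit, > 166000 nM. Compound 3 therefore has no number of its own, and its place is the limit of > 166000 nM in this assay, at which 2 of the 3 values shown sit.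

The next compound, compound 4 `OC[C@H]1O[C@@H](n2cnc3c(NCc4cc(O)cc(O)c4)ncnc32)[C@H](O)[C@@H]1O`, differs from compound 3 in a single place: 3,5-dihydroxyphenyl in place of 2,3,6-trifluorophenyl on a saturated chain carbon bound to a nitrogen on an aromatic ring. The new group, 3,5-dihydroxyphenyl, sits on a saturated chain carbon bound to a nitrogen on an aromatic ring.

Going by the values given here, two measured steps bear on this change: an at least 1.8-fold higher number from compound 1 to compound 2 (0.27 log units; that floor lies within the scatter), and an at least 1.8-fold higher number from compound 1 to compound 3 (0.27 log units; that floor lies within the scatter). Neither floor goes beyond the scatter. The third, a step that the two limits leave unreadable from compound 2 to compound 3, gives no size at all. None of these steps involves the incoming group, so they offer only weak guidance. Among the compounds with values here, the one firm number remains that of compound 1, at 89000 nM, and it suggests that a change of this group alone need not move the result far. The expected outcome is an at least 1.3-fold lower number from compound 3 to compound 4 (0.14 log units; that floor lies within the scatter), a small move toward a lower number at most, and a further limit would be no surprise. For compound 4 the estimated value is 120000 nM, with an expected range from 40000 nM to 200000 nM.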

Compound 4, half-maximal inhibitory concentration: > 166000 nM
Compound 4: only a limit was reported (the forecaster's own chance of this, stated with the estimate: 50%); middle value at least 1.3-fold (0.14 log units) from the limit.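

With compound 4, a ring bearing hydroxyl groups now sits at this place, on a saturated chain carbon bound to a nitrogen on an aromatic ring, yet in this assay compound 4 is still reported only as a limit, like the fluorinated compound 2 and compound 3, so exchanging the fluorines for hydroxyl groups yields no readable gain. Going by these compounds alone, the steps from compound 2 and from compound 3 to compound 4 cannot be read, as both ends are limits, and the only readable step is an at least 1.8-fold higher number from compound 1 to compound 4 (0.27 log units; that floor lies within the scatter), so no order can be claimed for this pair. The new result adds one more compound to the group at the limit, and compound 1 alone keeps a number: the limit of > 166000 nM in this assay, at which 3 of the 4 values shown sit.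

On these data alone, what stays open is how far below or above the limit compound 2, compound 3 and compound 4 really lie, and whether they differ from one another at all. As far as these compounds go, it is also open whether an amine or a carboxylic acid on this ring, or a longer chain between the ring and the nitrogen, would give a clearly lower number than compound 1 shows.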